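Urea to benzamide on the shared core: compound 4 expected weaker

The compounds below may be only part of what the source reports. "The series", "measured", "known", "first", "only" and "open" are said of these compounds alone.

Compound 3 `COc1cc(-c2nn(-c3cccc(NC(=O)Nc4ccc(Cl)c(C(F)(F)F)c4)c3)cc2-c2ccncc2)ccc1Cl` gives 1520 nM in a functional assay on TK-10 cells (Homo sapiens) for inhibition, read by sulforhodamine B assay, with a stated time of 48 h (a lower number here means a stronger inhibitor of growth, a higher number a weaker inhibitor of growth), the second highest of the three numbers; compound 2 `COc1cc(-c2nn(-c3cccc(NC(=O)Nc4cccc(C(F)(F)F)c4)c3)cc2-c2ccncc2)ccc1Cl` gives 1310 nM, and a 1.2-fold higher number from compound 2 to compound 3 (0.06 log units; within the scatter). Compound 1 `COc1cc(-c2nn(-c3cccc(NC(=O)c4ccc(Cl)c(C(F)(F)F)c4)c3)cc2-c2ccncc2)ccc1Cl` gives 20400 nM, and a 13-fold lower number from compound 1 to compound 3 (1.13 log units; beyond the scatter). Compound 4 `COc1cc(-c2nn(-c3cccc(NC(=O)c4ccccc4)c3)cc2-c2ccncc2)ccc1Cl` differs from compound 3 by phenyl in place of (4-chloro-3-(trifluoromethyl)phenyl)amino on a carbonyl carbon. This change reverses the amide-to-urea step seen as a 13-fold lower number from compound 1 to compound 3 (1.13 log units; beyond the scatter) and a 16-fold lower number from compound 1 to compound 2 (1.19 log units; beyond the scatter), both large, and also strips the chloro and trifluoromethyl groups, for which no step among these compounds exists. Compound 4 is therefore expected to return toward the number of compound 1, with a 13-fold higher number from compound 3 to compound 4 (1.12 log units; beyond the scatter) as an estimated step. The estimate for compound 4 is 20000 nM, with a range from 6000 nM to 70000 nM.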

Compound 4, concentration for 50% growth inhibition: 7000 nM
For compound 4 the middle estimate is 2.9-fold (0.46 log units) above the measured one; the range from low to high includes it.
By their numbers in this assay, from the lowest: compounds 2 and 3 (each within the scatter of the next); then compound 4; then compound 1.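

Compound 4 has no substituents on its phenyl, yet in this assay it stays a weaker inhibitor of growth than both ureas, with a 4.6-fold higher number from compound 3 to compound 4 (0.66 log units; beyond the scatter) and a 5.3-fold higher number from compound 2 to compound 4 (0.73 log units; beyond the scatter) in this comparison. Among the amides, however, the plain phenyl on the carbonyl carbon outperforms the 4-chloro-3-(trifluoromethyl)phenyl, with a 2.9-fold lower number from compound 1 to compound 4 (0.46 log units; beyond the scatter) on this change. No measurement shown here explains either result. As far as these compounds go, it remains open how a urea carrying an unsubstituted phenyl would compare with compound 2. Also open, from the compounds shown here alone, is how an amine or a carboxylic acid on the phenyl of compound 4 would read.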